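One fluoro added to compound 2

This account rests on a few compounds, and the source may have more. Where it says the series, first, only, none or still open, it means among the compounds named here.

In an ADME assay on a cell-free system (plasma, Mus musculus) for metabolic stability, read by LC-MS, tested at 2 uM (a lower number here means that the compound disappears faster, a higher number that the compound lasts longer), the measured compounds are:
compound 1 (`COc1cc(-c2cn(C(=O)NCCCCc3ccccc3)c(=O)o2)ccc1F`) with > 2 h as its reading
compound 2 (`CN1CCC(c2cccc(-c3cn(C(=O)NCCCCc4ccccc4)c(=O)o3)c2)CC1`) with > 2 h as its reading

Compound 2 gives > 2 h as a limit of the assay and not a number. Compound 1 gives a limit too, so the two cannot be ranked (the limit of > 2 h in this assay, at which 2 of the 2 values shown sit). Compound 3 (`CN1CCC(c2cc(-c3cn(C(=O)NCCCCc4ccccc4)c(=O)o3)ccc2F)CC1`) is compound 2 with fluoro in place of hydrogen on an aromatic carbon. Going by the values given here, no measured pair shows what such a change does. Resting on compound 2 and its limit (the limit of > 2 h in this assay, at which 2 of the 2 values shown sit), the expected step (a step that the limit leaves unreadable from compound 2 to compound 3) is none beyond the usual scatter, in either direction. For compound 3 the estimate is 3 h with an expected range from 1.5 h to 6 h in this assay.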

Compound 3, half-life in the Mus musculus assay: > 2 h
Compound 3: only a limit was reported; the forecaster's own chance of this, stated with the estimate: 85%; the middle value is on the limit's open side.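

In the Mus musculus assay compound 1 gives > 2 h, which is a limit and not a number. In the Mus musculus assay compound 2 gives > 2 h, which is also a limit. In the Mus musculus assay compound 3 gives > 2 h, which is also a limit. In the Mus musculus assay compound 1, compound 2 and compound 3 all give a limit and not a number, so no step between them can be read: the limit of > 2 h in the Mus musculus assay, at which 3 of the 3 values shown sit.

How long each of these compounds actually lasts, and whether fluoro in place of hydrogen changes that, stays open.

In a physicochemical assay for solubility, read by HPLC, in phosphate buffer, measured as kinetic solubility, with a stated time of 1 h, at pH 7.4, tested at 250 uM (on this read-out lower numbers stand for lower solubility and higher numbers for higher solubility), compound 2 gives 70000 nM and compound 3 gives 30000 nM. In the physicochemical assay fluoro in place of hydrogen on an aromatic carbon goes with a 2.3-fold lower number from compound 2 to compound 3 (0.37 log units; beyond the scatter).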